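Furan-to-pyridine swap on the shared core, topoisomerase inhibition

The source may report more compounds than this note shows. Statements on the series, on what has been measured and on what is new or still open speak of the compounds shown alone.

Measured so far:
compound 1 `Clc1ccc(-c2cc(-c3ccoc3)cc(-c3ccco3)n2)s1` gives 9.6%
compound 2 `Cc1ccc(-c2cc(-c3ccoc3)cc(-c3ccc(Cl)s3)n2)o1` gives 13.2%

In an assay on isolated protein for inhibition of DNA topoisomerase 1 (Homo sapiens), with a stated time of 30 min, tested at 100 uM (a higher number here means more inhibition at the concentration tested (going by the name of the read-out), a lower number less inhibition), compound 1 gives 9.6%, the lower of the two numbers at hand, with compound 2 as its nearest neighbour at 13.2%. For the measured compounds named here, the single measured step, a number 3.6 percentage points higher from compound 1 to compound 2 (within the scatter), is within the scatter, so the two measured compounds cannot be ordered against each other.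

Compound 3 `Clc1ccc(-c2cc(-c3ccoc3)cc(-c3ccccn3)n2)s1` is not yet measured. It differs from compound 1 as follows: pyridin-2-yl in place of furan-2-yl on an aromatic carbon. Going by the values given here, no measured step bears on this kind of change; the only step available, a number 3.6 percentage points higher from compound 1 to compound 2 (within the scatter), concerns a methyl on an aromatic carbon and is itself within the scatter. There is therefore no basis in the numbers for expecting a step beyond the scatter in either direction from compound 1 to compound 3.

For compound 3 the estimate is 12%, with a range from 0% to 30%, which means an expected step of a number 2.4 percentage points higher from compound 1 to compound 3 (within the scatter). Among the compounds with values here, the range is wide because the one step known, a number 3.6 percentage points higher from compound 1 to compound 2 (within the scatter), tells nothing about a ring swap.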

Compound 3, a percentage reported as inhibition, at one concentration (the size of the read-out at that concentration, not a potency): 3.1%
The estimate for compound 3 lay 8.9 percentage points above the measured number; low and high end bracket the measured number.
By their numbers in this assay, from the lowest: compounds 3, 1 and 2 (each within the scatter of the next, the first and the last beyond it).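

In this assay the swap on this aromatic carbon next to the ring nitrogen gives a number 6.5 percentage points lower from compound 1 to compound 3 (within the scatter) so pyridin-2-yl and furan-2-yl cannot be told apart at this place, and the six-membered aromatic ring cannot be separated from the five-membered one. Set against the methylated ring, the same position gives a number 10.1 percentage points lower from compound 2 to compound 3 (beyond the scatter) and this modest step is the first in the series to pass the scatter, even though neither the methyl step nor the step from furan-2-yl to pyridin-2-yl does so alone. No measurement at hand bears on the origin of this separation.

Still open, on these data alone, is whether any group at this place can carry inhibition well clear of what compound 2 gives at 13.2% and whether an amine, a carboxylic acid or a longer chain would read differently from the aromatic rings seen so far. Also open, as far as these compounds go, is what a methyl on the pyridin-2-yl group would do, as the step between the two compounds ties the loss of the methyl to the change of ring.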